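Aryl change from compound 2 to compound 3

A few compounds are considered here, and "the series" means these few. Any claim that something is new, unique, unknown or untested is made for them only; others in the source may bear on it.

Measured so far in a functional assay on MCF7 cells (Homo sapiens) for antiproliferative activity, read by MTT assay, with a stated time of 72 h; on this read-out higher numbers stand for weaker inhibition and lower numbers for stronger inhibition:
- compound 1 `COc1cc(-n2cnc3ccc(-c4cccc(C)c4C)cc32)cc(OC)c1OC` gives 2150 nM
- compound 2 `COc1cc(-n2cnc3ccc(-c4ccc(Cl)cc4Cl)cc32)cc(OC)c1OC` gives 5420 nM

Of the two numbers, compound 2 at 5420 nM holds the higher, with compound 1 its nearest neighbour. Next is compound 3 `COc1cc(-n2cnc3ccc(-c4ccc(F)cc4)cc32)cc(OC)c1OC`, which differs from compound 2 at one place: 4-fluorophenyl in place of 2,4-dichlorophenyl on an aromatic carbon. For the measured compounds named here, the only measured step at this carbon is a 2.5-fold higher number from compound 1 to compound 2 (0.40 log units; beyond the scatter) and it is modest. Going by the values given here, one step sets no trend, and no measured compound carries the 4-fluorophenyl group. A change of similar modest size is therefore expected, leaning towards compound 1 and a lower number. The expected change is a 2.2-fold lower number from compound 2 to compound 3 (0.34 log units; beyond the scatter) in this assay but its direction remains uncertain. Compound 3 is estimated at 2500 nM within an expected range from 900 nM to 7000 nM as the working figure.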

Compound 3, half-maximal inhibitory concentration: 1770 nM
Compound 3: middle estimate off by 1.4-fold (0.15 log units), on the high side; low and high end bracket the measured number.
By their numbers in this assay, from the lowest: compounds 3 and 1 (each within the scatter of the next); then compound 2.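

In this assay, 2,4-dichlorophenyl now stands apart from both other aryl groups at this aromatic carbon, with a 2.5-fold higher number from compound 1 to compound 2 (0.40 log units; beyond the scatter) and a 3.1-fold lower number from compound 2 to compound 3 (0.49 log units; beyond the scatter) both beyond the scatter, so compound 2 is the weakest of the three. 4-Fluorophenyl and 2,3-dimethylphenyl cannot be separated, as a 1.2-fold lower number from compound 1 to compound 3 (0.08 log units; within the scatter) lies within the scatter, so quite different substitution on this ring gives the same level of inhibition here. No supporting evidence bears on why the dichloro compound falls behind.

The step to compound 3 changes both the halogen and the number of ring substituents, so 4-chlorophenyl and unsubstituted phenyl would be needed to separate the two. Going by these compounds, how an amine or a carboxylic acid on this ring would read also remains open.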